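The source may hold more compounds than are shown below. What is called first, only, known or untested is meant among the compounds shown, and "the series" means these compounds.

Measured so far in a functional assay on A549 cells (Homo sapiens) for antiproliferative activity, read by MTT assay, with a stated time of 24 h; on this read-out lower numbers stand for stronger inhibition and higher numbers for weaker inhibition:
compound 1, `COc1ccc(-c2cc(C(=O)/C=C/c3ccccc3)nc3cc(-c4ccccc4)nn23)cc1OC`: 18600 nM
compound 2, `COc1ccc(/C=C/C(=O)c2cc(-c3cc(OC)c(OC)c(OC)c3)n3nc(-c4ccccc4)cc3n2)cc1OC`: 20500 nM

Compound 1 holds the lower of the two numbers in this assay, but the gap to compound 2 is within the usual scatter, so the two cannot be told apart on these data. Going by the values given here, both values sit in the weakly active range; no step between measured compounds differing in one place is available, so the series gives no guide to the size of a single change.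

Compound 3, `COc1ccc(-c2cc(/C=C/C(=O)c3ccc(Cl)cc3)nc3cc(-c4ccccc4)nn23)cc1OC`, is the compound to be measured next. It differs from compound 1 as follows: 2-((4-chlorophenyl)carbonyl)ethenyl in place of (2-phenylethenyl)carbonyl on an aromatic carbon. The place of the change is the same aromatic carbon of the shared core.

Among the compounds with values here, with no measured step of this kind, the change is expected to be small, and in either direction no further than the scatter would allow. Taking a modest move toward a lower number as the middle case, the expected step is a 1.2-fold lower number from compound 1 to compound 3 (0.09 log units; within the scatter). Compound 3 is therefore estimated at 15000 nM in this assay, within a range of 5000 nM to 45000 nM.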

Compound 3, half-maximal inhibitory concentration: 15400 nM
Beside the measured number, compound 3's estimate is 1.0-fold (0.01 log units) below it; measured number inside the range.
By their numbers in this assay, from the lowest: compounds 3, 1 and 2 (each within the scatter of the next).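

In this assay the series now has its first step at the aromatic carbon next to the ring nitrogen: 2-((4-chlorophenyl)carbonyl)ethenyl in place of (2-phenylethenyl)carbonyl gives a 1.2-fold lower number from compound 1 to compound 3 (0.08 log units; within the scatter), so this exchange leaves the number within the scatter. The position therefore tolerates a swap that both reverses the order of carbonyl and ethenyl on the core and adds a chlorine to the phenyl ring, with no readable gain or loss on this read-out. No measurement available here accounts for this result.

The two parts of the swap stay joined, since neither compound 1 nor compound 3 carries the reversed chain without the chlorine or the chlorine without the reversed chain, so the contribution of each part cannot be read. From the compounds shown here alone, it also remains open whether a dimethylamino group or a carboxylic acid on that phenyl ring, or a saturated chain in place of the ethenyl link, would give a step beyond the scatter at this position.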